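The source may hold more compounds than are shown below. What is called first, only, known or untested is meant among the compounds shown, and "the series" means these compounds.

In a functional assay on the whole organism for inhibition, with Scenedesmus acutus as the target (a higher number here means a weaker inhibitor, a lower number a stronger inhibitor), compound 1 `O=C(O)c1cc(N2C(=O)C3=C(CCCC3)C2=O)ccc1Cl` reads > 100000 nM, which is a limit of the assay and not a number. Within the data shown here, compound 2 `CC(C)COC(=O)c1cc(N2C(=O)C3=C(CCCC3)C2=O)ccc1Cl`, with isobutyl in place of hydrogen on an oxygen next to a carbonyl group, gives 977 nM, the only actual number available so far. Among the measured compounds shown here, the single measured step is an at least 100-fold lower number from compound 1 to compound 2 (2.01 log units; beyond the scatter).

Compound 3 `CCC(C)OC(=O)c1cc(N2C(=O)C3=C(CCCC3)C2=O)ccc1Cl` keeps the shared core and has sec-butyl in place of isobutyl on an oxygen next to a carbonyl group. The step to compound 2 bears on this change only loosely. At an at least 100-fold lower number from compound 1 to compound 2 (2.01 log units; beyond the scatter), it shows how far the number can move when a chain replaces hydrogen, but it compares no chain with another. The new change swaps one chain for another with the same atoms, so no large shift is expected in this assay, and no direction can be favoured. The expected change is a 1.0-fold higher number from compound 2 to compound 3 (0.01 log units; within the scatter). For compound 3 the estimated value is 1000 nM, with the expected range running from 300 nM to 3500 nM.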

Compound 3, half-maximal inhibitory concentration: 1100 nM
Estimate against measurement, compound 3: 1.1-fold (0.04 log units) below; the measured number falls inside the stated range.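

In this assay, the exchange of isobutyl for sec-butyl on an oxygen next to a carbonyl group gives a 1.1-fold higher number from compound 2 to compound 3 (0.05 log units; within the scatter), so this assay does not separate these two chains, which have the same atoms joined differently. Among these compounds, this is the first comparison of one chain with another at this position, and it shows that moving from one of these branched four-carbon chains to the other leaves the reading within the scatter, whereas replacing hydrogen with sec-butyl gives an at least 90-fold lower number from compound 1 to compound 3 (1.95 log units; beyond the scatter), a large step of the same kind as the one seen with isobutyl. The true size of both large steps stays unknown, since the reading of compound 1 is a limit and not a number: the limit of > 100000 nM in this assay, at which 1 of the 3 values shown sits.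

What the compounds shown leave open is how far this tolerance extends, since two closely related chains cannot show whether a methyl group, a straight n-butyl chain or a longer chain such as n-octyl on the same oxygen would read alike. From the compounds shown here alone, it is also open whether an amide in place of the ester link would keep the reading seen with compound 2 and compound 3.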